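This account rests on a few compounds, and the source may have more. Where it says the series, first, only, none or still open, it means among the compounds named here.

Working notes on the aryloxy-piperidine series.

Compound 1 `c1cc2c(c(OC3CCN(c4ccc(-n5ccnc5)nn4)CC3)c1)CCC2` is measured in an assay on microsomes from liver for inhibition of acyl-CoA desaturase 1 (Rattus norvegicus) (a higher number here means a weaker inhibitor, a lower number a stronger inhibitor), at 10 nM. Among the three numbers so far this is the low end: compound 3 `CC(C)Cc1nnc(-c2ccc(N3CCC(Oc4ccccc4C(F)(F)F)CC3)nn2)o1` gives 15 nM in this assay, which lies within the scatter of compound 1, while compound 2 `CC(C)(C)c1nnc(-c2ccc(N3CCC(Oc4ccccc4C(F)(F)F)CC3)nn2)o1` gives 980 nM, far above it. Among the compounds with values here, the one single-point step in the set, a 65-fold lower number from compound 2 to compound 3 (1.82 log units; beyond the scatter), concerns a substituent on an aromatic carbon of a different terminal ring and so does not bear directly on the change considered here.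

Compound 4 `CCc1cccc(OC2CCN(c3ccc(-n4ccnc4)nn3)CC2)c1` is not yet measured. It differs from compound 1 in one place: 3-ethylphenyl in place of 2,3-dihydro-1H-inden-4-yl on an oxygen on a saturated carbon. Within the data shown here, no measured pair in the set reports the effect of exchanging a fused bicyclic aryloxy group for a singly substituted phenyl ether at this position, so the expectation rests on the size of the group retained rather than on a precedent. The change is therefore expected to give a modest step in this assay, if any, leaning toward a higher number, a 2.5-fold higher number from compound 1 to compound 4 (0.40 log units; beyond the scatter). For compound 4 the estimate in this assay is 25 nM, with a range from 6 nM to 110 nM.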

Compound 4, half-maximal inhibitory concentration: 38 nM
Estimate against measurement, compound 4: 1.5-fold (0.18 log units) below; measured number inside the range.
By their numbers in this assay, from the lowest: compounds 1 and 3 (each within the scatter of the next); then compound 4; then compound 2.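

Within the data shown here, replacing the 2,3-dihydro-1H-inden-4-yl group with 3-ethylphenyl, on an oxygen on a saturated carbon, gives the first measured change at this group in this assay, with a 3.8-fold higher number from compound 1 to compound 4 (0.58 log units; beyond the scatter). The step is beyond the scatter but modest, so in this one pair the five-membered non-aromatic ring is not required for a number in the same low range, though its removal, together with the change from 9 to 8 heavy atoms, does carry a measurable cost. Nothing available explains the step, and no supporting measurement bears on this result.

A single pair cannot separate loss of the ring from the presence of an open ethyl chain, so it remains unclear which of the two accounts for the step. From the compounds shown here alone, it also remains open how a methyl, a propyl chain or a methoxy group in place of the ethyl, or an unsubstituted phenyl, would read in this assay with the rest of compound 4 kept the same.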